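Dicyanoethenyl in place of the thienyl ketone

The compounds below may be only part of what the source reports. "The series", "measured", "known", "first", "only" and "open" are said of these compounds alone.

Series notes. The shared core is that of compound 1 `CC1(C)C=C(n2ccccc2=O)c2cc(C(=O)c3cccs3)ccc2O1`. In a functional assay (trachea) with Rattus norvegicus as the target (a lower number here means a less potent compound, a higher number a more potent compound, by a factor of ten per unit of this negative logarithm), compound 1 gives 5.84. Compound 2 `CC1(C)C=C(n2ccccc2=O)c2cc(C(=O)c3ccccc3[N+](=O)[O-])ccc2O1` gives 5.64 and compound 3 `CC1(C)C=C(n2ccccc2=O)c2cc(C(=O)c3ccccc3C(F)(F)F)ccc2O1` gives 5.78. Compound 1 holds the highest of the three numbers, but both neighbours lie within the scatter of it: a number 0.20 log units lower from compound 1 to compound 2 (within the scatter) and a number 0.06 log units lower from compound 1 to compound 3 (within the scatter), and between the two aryl variants a number 0.14 log units higher from compound 2 to compound 3 (within the scatter). Nothing here separates the three compounds.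

Compound 4 `CC1(C)C=C(n2ccccc2=O)c2cc(C=C(C#N)C#N)ccc2O1` is the next case. 2,2-dicyanoethenyl in place of (thiophen-2-yl)carbonyl on an aromatic carbon The three measured steps all swap one aromatic group on the carbonyl for another while the carbonyl stays; none of them removes the carbonyl or puts in an open-chain group with nitriles, so they bear on the new step only loosely. What they do show is that the part of the molecule being altered tolerated three different groups without a shift beyond the scatter. The expectation for compound 4 is therefore a small step, a number 0.24 log units lower from compound 1 to compound 4 (within the scatter), most likely within the scatter but with a wider margin than usual because the carbonyl itself is gone. The estimate for compound 4 in this assay is 5.6, within a range of 5 to 6.2.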

Compound 4, logarithm of the reciprocal of the active concentration, log(1/C): 6.3
The estimate for compound 4 lay 0.70 log units below the measured number; measured number above the stated range.
By their numbers in this assay, from the lowest: compounds 2, 3 and 1 (each within the scatter of the next); then compound 4.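

In this assay, going by these compounds alone, the exchange of (thiophen-2-yl)carbonyl for 2,2-dicyanoethenyl gives a number 0.46 log units higher from compound 1 to compound 4 (beyond the scatter) and is the only step so far that lies beyond the scatter. The position therefore responds to some changes, whereas the earlier exchanges of one aromatic group for another on the carbonyl left the number within the scatter. Compound 4 also shows that neither the carbonyl nor a ring in this group is needed to reach the highest number in the series, since an open-chain group with two nitriles on the same aromatic carbon does so. No measurement on hand accounts for the rise.

As far as these compounds go, this one comparison removes the carbonyl and the thiophene ring and brings in the nitriles all at once, so the share of each in the step stays open. A single nitrile on the ethenyl group, a carboxylic acid in place of the nitriles, or a simple acetyl group at this aromatic carbon would bear on that question.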